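Fluoro to Methoxy in a Series With Little Spread

The source may hold more compounds than are shown below. What is called first, only, known or untested is meant among the compounds shown, and "the series" means these compounds.

Compound 1 `Fc1ccc2[nH]c(-c3cn(-c4ccccc4)nc3-c3ccccc3)nc2c1` gives 1720 nM in a functional assay on A549 cells (Homo sapiens) for antiproliferative activity, read by MTT assay, with a stated time of 48 h (a lower number here means a stronger inhibitor, a higher number a weaker inhibitor), and compound 2 `COc1ccc2[nH]c(-c3cn(-c4ccccc4)nc3-c3ccc(F)cc3)nc2c1` gives 1960 nM in the same test. Compound 3 `COc1ccc(-c2nn(-c3ccccc3)cc2-c2nc3cc(F)ccc3[nH]2)cc1` gives 1980 nM and sits within the usual scatter of both, so these three numbers cannot be ranked.

The next structure is compound 4 `COc1ccc(-c2nn(-c3ccccc3)cc2-c2nc3cc(OC)ccc3[nH]2)cc1` which differs from compound 3 at one place. The counted change is methoxy in place of fluoro on an aromatic carbon and in words it is methoxy in place of fluoro on an aromatic carbon.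

Two measurements offer some guidance, though neither isolates this swap. Within the data shown here, the one measured step is a 1.2-fold higher number from compound 1 to compound 3 (0.06 log units; within the scatter) and it lies within the scatter, but it adds methoxy in place of hydrogen at a different place in the molecule. Compound 4 carries methoxy on the same aromatic carbon as compound 2 and compound 2 gives 1960 nM which lies within the scatter of compound 3, although the two also differ elsewhere.

No shift beyond the scatter is therefore expected, and the estimated change is a 1.0-fold higher number from compound 3 to compound 4 (0.00 log units; within the scatter) in this assay for this pair. For compound 4 the estimate is 2000 nM with an expected range from 1100 nM to 3800 nM as the likely span.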

Compound 4, half-maximal inhibitory concentration: 22700 nM
Beside the measured number, compound 4's estimate is 11-fold (1.05 log units) below it, and the stated range ends below it.
By their numbers in this assay, from the lowest: compounds 1, 2 and 3 (each within the scatter of the next); then compound 4.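

Among these compounds, this aromatic carbon now turns out to matter: in this assay, putting methoxy in place of fluoro here gives an 11-fold higher number from compound 3 to compound 4 (1.06 log units; beyond the scatter), a large step beyond the scatter, whereas the earlier compounds gave numbers that could not be ranked. The same kind of swap at a different place in the molecule gives a 12-fold higher number from compound 2 to compound 4 (1.06 log units; beyond the scatter), so compound 4, the only compound shown with two methoxy groups, stands apart, while compound 2 and compound 3, each with one methoxy and one fluoro, show no such rise. Nothing available here explains this loss of activity.

The compounds shown leave open whether the rise depends on having both methoxy groups together or on methoxy at this carbon alone in some other setting. They also leave open how a hydroxyl, an ethoxy or an amine on this same carbon would compare with fluoro and methoxy.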